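The source may hold more compounds than are shown below. What is called first, only, known or untested is meant among the compounds shown, and "the series" means these compounds.

Measured compounds in a functional assay on MDA-MB-231 cells (Homo sapiens) for inhibition, read by MTT assay, with a stated time of 48 h; a lower number here means a stronger inhibitor, a higher number a weaker inhibitor:

- Compound 1 `CN1CCN(c2ccc(Nc3ncc4c(n3)N(C3CCCC3)CC(=O)N4C)nc2)CC1`; compound 1 gives 23700 nM.
- Compound 2 `CN1C(=O)CN(C2CCCC2)c2nc(Nc3ccc(N4CCCCC4)cn3)ncc21`; compound 2 gives 29300 nM.
- Compound 3 `CC1CCN(c2ccc(Nc3ncc4c(n3)N(C3CCCC3)CC(=O)N4C)nc2)CC1`; for compound 3 the assay reports only a limit, > 30000 nM.

Compound 2 holds the higher of the two numbers that are not limits; the nearest is compound 1, and the two sit within the scatter of each other, as a 1.2-fold higher number from compound 1 to compound 2 (0.09 log units; within the scatter) shows. The third value is a limit of the assay, (the limit of > 30000 nM in this assay, at which 1 of the 3 values shown sits), and the floors derived from it, an at least 1.2-fold higher number from compound 1 to compound 3 (0.10 log units; that floor lies within the scatter) and an at least 1.0-fold higher number from compound 2 to compound 3 (0.01 log units; that floor lies within the scatter), also stay within the scatter.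

Compound 4 `CCN1C(=O)CN(C2CCCC2)c2nc(Nc3ccc(N4CCCCC4)cn3)ncc21` is not yet measured. It differs from compound 2 by methyl in place of hydrogen on a saturated chain carbon bound to an amide-type nitrogen in a ring. Among the measured compounds shown here, the closest analogy among the measured steps is the one from compound 2 to compound 3, a methyl added on a saturated ring carbon elsewhere in the molecule, which gave an at least 1.0-fold higher number from compound 2 to compound 3 (0.01 log units; that floor lies within the scatter), a floor within the scatter. For the measured compounds named here, no measured step moves the number beyond the scatter. The step from compound 2 to compound 4 is therefore expected to be a 1.0-fold higher number from compound 2 to compound 4 (0.01 log units; within the scatter), with no direction beyond the scatter. Compound 4 is estimated at 30000 nM, between 14000 nM and 60000 nM, with a fair chance that only a limit is reported.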

Compound 4, half-maximal inhibitory concentration: 28200 nM
Compound 4: the middle estimate sits 1.1-fold (0.03 log units) above what was measured; the measured number falls inside the stated range.
By their numbers in this assay, from the lowest: compounds 1, 4 and 2 (each within the scatter of the next). At a limit, above all of these: compound 3.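

Among the compounds shown here, the change from methyl to ethyl, on a saturated chain carbon bound to an amide-type nitrogen in a ring, is the first step here that lies on the shared core rather than in the piperidin-1-yl or 4-methylpiperazin-1-yl group. In this assay, the step reads a 1.0-fold lower number from compound 2 to compound 4 (0.02 log units; within the scatter), so this position adds a second region of the molecule where a one-carbon extension does not separate two compounds beyond the scatter. Compound 3 remains the only compound given as a limit of the assay: the limit of > 30000 nM in this assay, at which 1 of the 4 values shown sits.

Still open is whether this position can produce any step beyond the scatter, since methyl and ethyl are the only groups shown on the amide-type nitrogen, and a longer chain such as n-butyl, a chain ending in an amine or a carboxylic acid, or a plain hydrogen there could test that. Also open is which part of the shared core or its substituents governs the number in this assay, as no step among the compounds shown lies beyond the scatter.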